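The source may report more compounds than this note shows. Statements on the series, on what has been measured and on what is new or still open speak of the compounds shown alone.

Working notes on the series.

Compound 1 `C/N=C(\S)OC[C@H]1OC(n2cnc3c(NC4CCOC4)ncnc32)[C@H](O)[C@@H]1O` carries the shared core with a thioimidate-type chain on the sugar hydroxymethyl oxygen. In an assay on DDT1 cells (Cricetulus griseus) for binding affinity to adenosine receptor A1 (Homo sapiens), read by radioligand binding (a lower number here means a stronger inhibitor, a higher number a weaker inhibitor), compound 1 gives 45 nM. Among the three measured numbers compound 1 stands second highest; the nearest is compound 2 and the furthest is compound 3. Compound 2 `CC/N=C(\S)OC[C@H]1OC(n2cnc3c(NC4CCOC4)ncnc32)[C@H](O)[C@@H]1O` gives 33 nM in this assay, and the step of a 1.4-fold lower number from compound 1 to compound 2 (0.13 log units; within the scatter) stays within the scatter. Compound 3 `CC(C)NC(=O)OC[C@H]1OC(n2cnc3c(NC4CCOC4)ncnc32)[C@H](O)[C@@H]1O` gives 78 nM; the step of a 1.7-fold higher number from compound 1 to compound 3 (0.24 log units; within the scatter) is also within the scatter, whereas a 2.4-fold higher number from compound 2 to compound 3 (0.37 log units; beyond the scatter) is a modest step beyond it.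

Compound 4 `CC(C)/N=C(\S)OC[C@H]1OC(n2cnc3c(NC4CCOC4)ncnc32)[C@H](O)[C@@H]1O` is not yet measured. It differs from compound 1 by isopropyl in place of methyl on a double-bonded nitrogen. Among the measured compounds shown here, the only measured step that bears on this change is a 1.4-fold lower number from compound 1 to compound 2 (0.13 log units; within the scatter), where a larger group on the same double-bonded nitrogen went with a small, within-scatter lowering of the number. The steps to compound 3 concern the whole chain and do not speak to this change. Nothing in the set shows a larger group at this site moving the number beyond the scatter, so the expected step of a 1.4-fold lower number from compound 1 to compound 4 (0.15 log units; within the scatter) is small and, if anything, toward a lower number. Compound 4 is therefore estimated at 32 nM in this assay, within a range from 13 nM to 80 nM.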

Compound 4, inhibition constant: 36 nM
Beside the measured number, compound 4's estimate is 1.1-fold (0.05 log units) below it; low and high end bracket the measured number.
By their numbers in this assay, from the lowest: compounds 2, 4, 1 and 3 (each within the scatter of the next, the first and the last beyond it).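

On a double-bonded nitrogen, isopropyl in place of methyl leaves the number in this assay within the scatter (a 1.3-fold lower number from compound 1 to compound 4 (0.10 log units; within the scatter)), and the step from the ethyl chain of compound 2 is also within it (a 1.1-fold higher number from compound 2 to compound 4 (0.04 log units; within the scatter)), so methyl, ethyl and isopropyl at this site cannot be told apart in the three compounds that carry them. Compound 4 also supplies a comparison that compound 2 could not, since compound 3 and compound 4 carry chains of equal heavy-atom count, one with oxygen and one with sulfur, and this exchange is a modest step beyond the scatter (a 2.2-fold lower number from compound 3 to compound 4 (0.34 log units; beyond the scatter)). No measurement in hand accounts for the flat run on the nitrogen or for the gap between the oxygen and sulfur chains.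

On these data alone, whether this tolerance on the nitrogen extends past isopropyl, to a longer chain such as n-butyl, to a cyclohexyl ring or to a phenyl ring, remains open. Also open is whether the gap between the sulfur and oxygen chains persists with methyl or ethyl on the nitrogen, as the compounds shown offer that comparison at isopropyl alone.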